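One Methyl Less: Expected Cytotoxicity of Compound 4

The compounds below may be only part of what the source reports. "The series", "measured", "known", "first", "only" and "open" are said of these compounds alone.

Among the measured compounds shown here, compound 3 `CCON=C1CCC(CN2C(C)CN(c3nc(=O)c4cc(C(F)(F)F)cc([N+](=O)[O-])c4s3)CC2C)CC1` gives 60.5 ug/mL in an ADME assay on Vero cells (Chlorocebus sabaeus) for cytotoxicity (on this read-out higher numbers stand for lower toxicity in this test and lower numbers for higher toxicity in this test), the only number among the three measured values. Compound 1 `CCON=C1CCC(CN2CCN(c3nc(=O)c4cc(C(F)(F)F)cc([N+](=O)[O-])c4s3)CC2)CC1` sits at the limit of > 64 ug/mL in this assay. Compound 2 `CCON=C1CCC(CN2CCN(c3nc(=O)c4cc(C(F)(F)F)cc([N+](=O)[O-])c4s3)C[C@@H]2C)CC1` also reaches the limit of > 64 ug/mL in this assay. The step that the two limits leave unreadable from compound 1 to compound 2 cannot be read from these two limits. Compound 4 `CCON=C1CCC(CN2CCN(c3nc(=O)c4cc(C(F)(F)F)cc([N+](=O)[O-])c4s3)CC2C)CC1` differs from compound 3 by hydrogen in place of methyl on a saturated ring carbon. For the measured compounds named here, the only measured step that bears on this change is unreadable, while the limit of > 64 ug/mL in this assay, at which 2 of the 3 values shown sit, shows both limits at the top of the measured range. Compound 4 is therefore expected to show no step beyond the scatter, a 1.1-fold higher number from compound 3 to compound 4 (0.02 log units; within the scatter). The estimate for compound 4 in this assay is 64 ug/mL, within 40 ug/mL to 100 ug/mL.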

Compound 4, half-maximal cytotoxic concentration: > 64 ug/mL
Compound 4 was reported as a limit; the forecaster's own chance of this, stated with the estimate: 60%; the middle value sits exactly at the limit.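

In this assay, among the compounds shown here, hydrogen in place of methyl on a saturated ring carbon gives an at least 1.0-fold higher number from compound 3 to compound 4 (0.02 log units; that floor lies within the scatter), the first step of this change with a readable floor. How far the step goes past that floor is unknown, and the steps from compound 1 and compound 2 to compound 4 cannot be read: the limit of > 64 ug/mL in this assay, at which 3 of the 4 values shown sit. Nor can any effect of configuration at this ring carbon be told from compound 2 and compound 4: the fact that one of compounds 2 and 4 is drawn with a defined configuration and the other without, at the place where they differ

On these data alone, whether an ethyl group or a hydroxymethyl group on this ring carbon would give a number rather than a limit in this assay stays open.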